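Bromo to dimethoxyphenyl at the meta position of an anilide

The source may report more compounds than this note shows. Statements on the series, on what has been measured and on what is new or still open speak of the compounds shown alone.

Measured compounds:
compound 1 `O=C(CCc1cccc2c1B(O)OC2)NC1CCCCC1` — > 100000 nM
compound 2 `O=C(CCc1cccc2c1B(O)OC2)Nc1ccc(Br)cc1` — 9200 nM
compound 3 `O=C(CCc1cccc2c1B(O)OC2)Nc1cccc(Br)c1` — 540 nM

Three amides built on a shared core were tested in a functional assay on SK-OV-3 cells (Homo sapiens) for antiproliferative activity, read by MTT assay, with a stated time of 72 h; a higher number here means a weaker inhibitor, a lower number a stronger inhibitor. Compound 1, the cyclohexyl amide, gives only a limit of the assay, > 100000 nM, as the evidence notes (the limit of > 100000 nM in this assay, at which 1 of the 3 values shown sits). Compound 2 gives 9200 nM, and compound 3 gives 540 nM, the lowest of the two numbers; the step of a 17-fold lower number from compound 2 to compound 3 (1.23 log units; beyond the scatter) and the step of an at least 180-fold lower number from compound 1 to compound 3 (2.26 log units; beyond the scatter) both exceed the scatter.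

Compound 4 `COc1cc(OC)cc(-c2cccc(NC(=O)CCc3cccc4c3B(O)OC4)c2)c1` has not been measured. It differs from compound 3 in one place: 3,5-dimethoxyphenyl in place of bromo on an aromatic carbon. For the measured compounds named here, no measured step changes the substituent at this position; the only steps on hand, an at least 10-fold lower number from compound 1 to compound 2 (1.03 log units; beyond the scatter), an at least 180-fold lower number from compound 1 to compound 3 (2.26 log units; beyond the scatter) and a 17-fold lower number from compound 2 to compound 3 (1.23 log units; beyond the scatter), alter the whole amide substituent or the placement of the bromo group. They show this part of the molecule carries weight but give no direction for a larger aryl group in place of bromo. The expected step for compound 4 is therefore a 1.3-fold higher number from compound 3 to compound 4 (0.11 log units; within the scatter), with wide uncertainty. Compound 4 is estimated at 700 nM, between 120 nM and 5000 nM.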

Compound 4, half-maximal inhibitory concentration: 44 nM
Compound 4: the middle estimate sits 16-fold (1.20 log units) above what was measured, and the stated range ends above it.
By their numbers in this assay, from the lowest: compound 4; then compound 3; then compound 2. At a limit, above all of these: compound 1.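

In this assay, the place held by bromo in compound 3 proves able to take a far larger group, and the exchange for 3,5-dimethoxyphenyl gives a 12-fold lower number from compound 3 to compound 4 (1.09 log units; beyond the scatter). For the compounds shown here, the earlier steps changed the whole amide substituent or moved the bromo group around the ring, whereas this one keeps the position meta to a large group and changes only what sits there, so it is the first sign that a substituent at this carbon sets the number in its own right, and that an added six-membered aromatic ring with two methoxy groups lowers it well beyond the scatter. Nothing on hand gives a reason for this gain, and it stands as an observation only.

From the compounds shown here alone, it remains open whether the added aromatic ring alone carries the step or its two methoxy groups share in it, which a plain phenyl or a 3-methoxyphenyl group would separate. Also open, going by these compounds, is whether 3,5-dimethoxyphenyl would act the same way in the place bromo holds in compound 2, and whether a pyridine ring or a morpholine would serve at this position.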